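A few compounds are considered here, and "the series" means these few. Any claim that something is new, unique, unknown or untested is made for them only; others in the source may bear on it.

Working notes on the series. Within the data shown here, compound 2 `ClCc1ccccc1Cn1cnc2c(Cl)nc(Cl)nc21` is one of two compounds measured in a functional assay on NCI-H23 cells (Homo sapiens) for cytotoxicity, read by sulforhodamine B assay, with a stated time of 48 h (a higher number here means that more compound is tolerated, a lower number that less compound is tolerated), where compound 2 gives 6310 nM. Compound 1 `ClCc1ccc(Cn2cnc3c(Cl)ncnc32)cc1` gives 7760 nM in this assay; the two values lie within the scatter of each other, so no order between compound 1 and compound 2 can be read from them. Among the measured compounds shown here, no pair of measured compounds differing in a single place is available, so no measured step exists to lean on. Compound 3 `ClCc1ccccc1Cn1cnc2c(Cl)ncnc21` differs from compound 2 by hydrogen in place of chloro on an aromatic carbon. Compound 1 also carries a single chloro on its core, and its value in this assay sits close to that of compound 2. On that basis the step from compound 2 to compound 3 is expected to be small, a 1.3-fold higher number from compound 2 to compound 3 (0.10 log units; within the scatter), if anything toward a higher number, and not clearly beyond the scatter. Compound 3 is therefore estimated at 8000 nM in this assay, with a range from 3500 nM to 18000 nM.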

Compound 3, concentration lethal to 50% of the cells: 9330 nM
For compound 3 the middle estimate is 1.2-fold (0.07 log units) below the measured one; the measured number falls inside the stated range.
By their numbers in this assay, from the lowest: compounds 2, 1 and 3 (each within the scatter of the next).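

In this assay the series now has its first single-place step: a 1.5-fold higher number from compound 2 to compound 3 (0.17 log units; within the scatter) with hydrogen in place of chloro on the aromatic carbon between two ring nitrogen atoms. The step lies within the scatter, so with the other chloro group retained, this exchange at this position produces no change that these numbers can resolve. Nothing available accounts for this result, and no cause can be assigned to it.

The compounds shown leave open whether an amine or a methoxy group on this carbon would also stay within the scatter of compound 3. They also leave open whether the same exchange would give a similarly small step at the remaining chloro position, or in a compound with a different substituent pattern.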